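Swapping the Phenoxy Ring: Clearance Expected for Compound 3

The source may report more compounds than this note shows. Statements on the series, on what has been measured and on what is new or still open speak of the compounds shown alone.

compound 1, `Cn1cc(-c2cc(S(N)(=O)=O)ccc2Oc2ccccc2)c2cc[nH]c2c1=O`: in an ADME assay on microsomes from liver (Homo sapiens) for metabolic stability, read by HPLC, using NADPH, with stated times of 5 min and 60 min, tested at 10 uM (on this read-out higher numbers stand for fast clearance and lower numbers for slow clearance), compound 1 gives < 43.4 mL/min/kg, which is a limit of the assay and not a number
compound 2, `Cn1cc(-c2cc(NS(C)(=O)=O)ccc2Oc2ccccc2C(F)(F)F)c2cc[nH]c2c1=O`: in this assay compound 2 gives 533 mL/min/kg

Among the compounds with values here, compound 2 is the only compound of the two with a numeric result in this assay, and that result sits at the fast-clearance end of the read-out. Compound 1 stands at the limit of < 43.4 mL/min/kg in this assay, at which 1 of the 2 values shown sits, so its true value is not known beyond that boundary, and the two compounds cannot be compared as numbers.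

Compound 3, `Cn1cc(-c2cc(NS(C)(=O)=O)ccc2Oc2ccc(F)cc2F)c2cc[nH]c2c1=O`, is not yet measured. It differs from compound 2 by 2,4-difluorophenyl in place of 2-(trifluoromethyl)phenyl on an oxygen on an aromatic ring. Within the data shown here, no measured pair in this set shows that change, so there is no step from which to read a direction. The step from compound 2 to compound 3 is therefore expected to be a 1.3-fold lower number from compound 2 to compound 3 (0.12 log units; within the scatter), a shift that would stay within the usual scatter of the assay rather than a clear move either way. On that basis compound 3 is estimated at 400 mL/min/kg in this assay, with a range from 170 mL/min/kg to 900 mL/min/kg.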

Compound 3, clearance: 155 mL/min/kg
For compound 3 the middle estimate is 2.6-fold (0.41 log units) above the measured one; measured number outside the range, below it.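

Within the data shown here, the change from 2-(trifluoromethyl)phenoxy to 2,4-difluorophenoxy gives the only step that can be read in this assay, a 3.4-fold lower number from compound 2 to compound 3 (0.54 log units; beyond the scatter). Among these compounds, this step lies beyond the usual scatter, so the group on this oxygen can move clearance even when the rest of the molecule stays the same, which the earlier compounds could not show. Still, this is one change in one pair of compounds, and nothing measured here explains why the number falls.

In this assay compound 1 gives < 43.4 mL/min/kg, which is a limit of the assay and not a number, and it differs from compound 2 and compound 3 in more than one place, so steps involving compound 1 cannot be read. As far as these compounds go, it remains open how clearance would respond to a 4-fluorophenyl or a 2-fluorophenyl at this position, which could separate the contribution of each fluorine, or to a cyclohexyl or a pyridine ring in place of the benzene ring, and whether the same swap would give a step of similar size on another core.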